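This account rests on a few compounds, and the source may have more. Where it says the series, first, only, none or still open, it means among the compounds named here.

Compound 1 `COc1ccc(N2CCN(Cc3csc(N)c3C(=O)c3ccc(Cl)cc3)CC2)cc1`: 0%
Compound 2 `Nc1scc(CN2CCN(c3ccc(OC(F)(F)F)cc3)CC2)c1C(=O)c1ccc(Cl)cc1`: 1%
Compound 3 `Nc1scc(CN2CCN(c3ccc(C(F)(F)F)cc3)CC2)c1C(=O)c1cccc(C(F)(F)F)c1`: 0%

Within the data shown here, in an assay on CHO cells for displacement of a labelled ligand from adenosine receptor A3 (Homo sapiens), read by scintillation counting, with a stated time of 120 min, tested at 10 uM (on this read-out lower numbers stand for less inhibition and higher numbers for more inhibition at the one concentration tested (going by the name of the read-out)), compound 1 gives 0%, the same figure as compound 3 and together with it the lowest of the three numbers; the only measured step, a number 1 percentage points higher from compound 1 to compound 2 (within the scatter), lies within the scatter. Compound 4 `Nc1scc(CN2CCN(c3ccccc3F)CC2)c1C(=O)c1ccc(Cl)cc1` differs from compound 1 by 2-fluorophenyl in place of 4-methoxyphenyl on an amine nitrogen in a ring. Among the measured compounds shown here, no measured step touches the group on the amine nitrogen in a ring, so nothing directly bears on this change; the one step available alters a different group and stays within the scatter, and all three measured compounds sit close to zero. The author therefore expects no step beyond the scatter, a number 2 percentage points higher from compound 1 to compound 4 (within the scatter), and estimates compound 4 at 2%, with a range from 0% to 12%.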

Compound 4, a percentage reported as inhibition, at one concentration (the size of the read-out at that concentration, not a potency): 0%
Compound 4: the middle estimate sits 2 percentage points above what was measured; the measured number falls inside the stated range.
By their numbers in this assay, from the lowest: compounds 1, 3, 4 and 2 (each within the scatter of the next).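

In this assay the group on the amine nitrogen in a ring now has steps of its own: 2-fluorophenyl in place of 4-methoxyphenyl gives no change at the digits printed from compound 1 to compound 4 (within the scatter) and 2-fluorophenyl in place of 4-(trifluoromethoxy)phenyl gives a number 1 percentage points lower from compound 2 to compound 4 (within the scatter) here. Across these three groups on that nitrogen, with the rest of the molecule held the same, the reading therefore stays within the scatter. No evidence given here accounts for this result. Still open, on these data alone, is whether a carboxylic acid or a longer chain on that nitrogen would move the reading beyond the scatter.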